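Dropping the chloro group from compound 2

This account rests on a few compounds, and the source may have more. Where it says the series, first, only, none or still open, it means among the compounds named here.

Of the compounds shown here, two of one family have been tested in a functional assay on the whole organism for positive allosteric modulation, with Rattus norvegicus as the target; on this read-out lower numbers stand for an effect already at smaller amounts and higher numbers for an effect only at larger amounts of compound. Compound 1, `Cc1nn(C)c2c1C(c1ccccc1)=NCCN2C`, carries a plain phenyl ring and a methyl group on its ring nitrogen. In this assay compound 1 gives 2.5 mg/kg. Compound 2, `Cc1nn(C)c2c1C(c1cccc(Cl)c1)=NCCN2CCCN(C)C`, carries a 3-chlorophenyl ring and a dimethylaminopropyl chain in place of that methyl. For compound 2 this assay reports only a limit, > 10 mg/kg, and not a number. On these data alone, compound 2 thus stands at the limit of > 10 mg/kg in this assay, at which 1 of the 2 values shown sits, so its true effective dose is unknown beyond that edge. Going by the values given here, compounds 1 and 2 differ in two places at once, so no single step between them can be read.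

Compound 3, `Cc1nn(C)c2c1C(c1ccccc1)=NCCN2CCCN(C)C`, has not yet been measured in this assay. It differs from compound 2 in one place: hydrogen in place of chloro on an aromatic carbon. Among the compounds with values here, since compound 2 is known only as a limit, no measured step shows what this change does. The expected step is an at least 1.2-fold lower number from compound 2 to compound 3 (0.09 log units; that floor lies within the scatter), toward a smaller dose, but with wide uncertainty. For compound 3 the estimate in this assay is 8 mg/kg, expected to fall between 2.5 mg/kg and 30 mg/kg.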

Compound 3, minimum effective dose: > 10 mg/kg
Compound 3: only a limit was reported; the forecaster's own chance of this, stated with the estimate: 40%; middle value at least 1.2-fold (0.09 log units) away from the limit.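

In this assay, going by these compounds alone, compound 1 and compound 3 share the plain phenyl ring and differ in one place, which gives the first step that can be read: an at least 4.0-fold higher number from compound 1 to compound 3 (0.60 log units; beyond the scatter). Replacing a hydrogen on a saturated chain carbon bound to a nitrogen with 2-(dimethylamino)ethyl, which turns the methyl of compound 1 into the dimethylaminopropyl chain of compound 3, therefore moves the effect to larger doses, and this shift appears without any chloro group present. The step from 3-chlorophenyl to phenyl cannot be read, because compound 2 and compound 3 are both reported only as a limit, so neither has a number to compare: the limit of > 10 mg/kg in this assay, at which 2 of the 3 values shown sit.

On these data alone, it remains open whether the chloro group changes the dose on a compound that keeps the small methyl group of compound 1, and how far the true doses of compound 2 and compound 3 lie beyond their limit. As far as these compounds go, it is also open whether a different chain in the same place, such as a hydroxyethyl group or a chain ending in a carboxylic acid, would stay close to compound 1 in this whole-organism read-out.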